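The source may hold more compounds than are shown below. What is called first, only, known or untested is meant among the compounds shown, and "the series" means these compounds.

The series is followed in a functional assay on DU-145 cells (Homo sapiens) for inhibition, read by trypan blue exclusion, with a stated time of 96 h; on this read-out higher numbers stand for weaker inhibition of growth and lower numbers for stronger inhibition of growth. Compound 1 `COc1ccc(/C=C(/SCc2ccc(Cl)cc2)C(=O)c2ccc(Cl)cc2)cc1` gives 10000 nM. Compound 2 `O=C(O)c1ccc(C(=O)/C(=C\c2ccc(Cl)c([N+](=O)[O-])c2)SCc2ccc(Cl)cc2)cc1` gives 1000 nM, the lowest number of the three measured. Compound 3 `CSc1ccc(/C=C(/SCc2ccc(Cl)cc2)C(=O)c2ccc(Cl)cc2)cc1` gives 25000 nM and stands at the highest number of the set; the step from compound 1 is a 2.5-fold higher number from compound 1 to compound 3 (0.40 log units; beyond the scatter), and the gap to compound 2 is wider still. So the one single-site change within the measured set, methylsulfanyl in place of methoxy on an aromatic carbon, moves the number upward.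

Compound 4 `CSc1ccc(/C=C(/SCc2ccc(Cl)cc2)C(=O)c2ccc(C(=O)O)cc2)cc1` is not yet measured. Against compound 3 the change is carboxy in place of chloro on an aromatic carbon; cut one bond further out it reads 4-chlorophenyl to 4-carboxyphenyl. For the measured compounds named here, no measured pair differs in this one place, so no step from the numbers bears on it directly. Going by the values given here, compound 2 is the only measured compound whose 4-carboxyphenyl matches that of compound 4, and it shows the lowest number of the set, but it differs from compound 3 in more than one place, so what its value shows cannot be split between the changes. For compound 4 the expected step is a 2.5-fold lower number from compound 3 to compound 4 (0.40 log units; beyond the scatter), toward a lower number, held loosely. The estimate for compound 4 in this assay is 10000 nM, between 2500 nM and 40000 nM.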

Compound 4, concentration for 50% growth inhibition: > 100000 nM
Compound 4 gave a limit, no number; the forecaster's own chance of this, stated with the estimate: 10%; middle value at least 10-fold (1.00 log units) from the limit.
By their numbers in this assay, from the lowest: compound 2; then compound 1; then compound 3. At a limit, above all of these: compound 4.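

In this assay compound 4 stands at a limit of the assay and gives no number: the limit of > 100000 nM in this assay, at which 1 of the 4 values shown sits. Carboxy in place of chloro on an aromatic carbon, para to a large group, gives an at least 4.0-fold higher number from compound 3 to compound 4 (0.60 log units; beyond the scatter), so with the 4-(methylsulfanyl)phenyl group held, this position does not tolerate the change, and the printed size of the step is only a bound. With the 4-carboxyphenyl group held, 4-(methylsulfanyl)phenyl in place of 4-chloro-3-nitrophenyl gives an at least 100-fold higher number from compound 2 to compound 4 (2.00 log units; beyond the scatter), so the lowest number of the set does not travel with the 4-carboxyphenyl group alone, and what that group does here depends on the aromatic group at the other end of the double bond.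

On these data alone, it remains open whether the same change from 4-chlorophenyl to 4-carboxyphenyl would also raise the number with 4-chloro-3-nitrophenyl held, which would show whether the loss belongs to the carboxy group in general or to this pairing. Also open, as far as these compounds go, is whether a methyl ester or a primary amide at the same place would return a measurable number with the 4-(methylsulfanyl)phenyl group held.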